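Replacing 3,3-dimethylazetidin-1-yl in compound 3

The compounds below may be only part of what the source reports. "The series", "measured", "known", "first", "only" and "open" are said of these compounds alone.

Measured values in a physicochemical assay for solubility, measured as kinetic solubility (on this read-out lower numbers stand for lower solubility and higher numbers for higher solubility), so far:
- compound 1 `Cc1cnc(NC(=O)c2cc(Oc3cnc(C(=O)N(C)C)cn3)c3cc(C)oc3c2)cn1` gives 176000 nM
- compound 2 `CCN(C)C(=O)c1cnc(Oc2cc(C(=O)Nc3cnc(C)cn3)cc3oc(C)cc23)cn1` gives 344000 nM
- compound 3 `Cc1cc2c(Oc3cnc(C(=O)N4CC(C)(C)C4)cn3)cc(C(=O)Nc3cnccn3)cc2o1` gives 78000 nM

Compound 3 stands lowest of the three, and its gaps to compound 1 and compound 2 both lie beyond the scatter. Compound 4 `Cc1cc2c(Oc3cnc(C(=O)N4CC5(COC5)C4)cn3)cc(C(=O)Nc3cnccn3)cc2o1` is unmeasured, and the change to it is a group of 7 heavy atoms (5 carbon, 1 nitrogen, 1 oxygen; 2 four-membered non-aromatic rings with 1 hetero atom each) in place of a group of 6 heavy atoms (5 carbon, 1 nitrogen; one four-membered non-aromatic ring with 1 hetero atom), on a carbonyl carbon on the same carbonyl carbon. Among the measured compounds shown here, the only measured step of a 2.0-fold higher number from compound 1 to compound 2 (0.29 log units; within the scatter) swaps methyl for hydrogen on a saturated chain carbon bound to an amide-type nitrogen, so it bears on this change only loosely. For the measured compounds named here, no measured pair covers this change directly. With compound 1 at 176000 nM as a nearby reference, a moderate rise is expected. The estimated step in this assay is a 2.2-fold higher number from compound 3 to compound 4 (0.34 log units; beyond the scatter) and carries wide uncertainty. For compound 4 the expected value is 170000 nM within an estimated range from 70000 nM to 400000 nM for now.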

Compound 4, solubility: 43000 nM
Compound 4: middle estimate off by 4.0-fold (0.60 log units), on the high side, outside the stated range (below it).
By their numbers in this assay, from the lowest: compounds 4 and 3 (each within the scatter of the next); then compounds 1 and 2 (each within the scatter of the next).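

In this assay, the change on the carbonyl carbon gives a 1.8-fold lower number from compound 3 to compound 4 (0.26 log units; within the scatter), the first step read at this position among the cyclic groups. Replacing 3,3-dimethylazetidin-1-yl with the group of two four-membered rings, which adds one hydrogen-bond acceptor, therefore produces no change that can be read beyond the scatter. Nothing available gives a cause for this result.

Compounds 3 and 4 differ from compounds 1 and 2 in more than one place, so no single-change comparison links these pairs. On these data alone, whether a morpholine or an azetidine bearing a carboxylic acid on this carbonyl carbon would give a step beyond the scatter remains open.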